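A Methyl Removed from the Shared Core of Compound 1

The source may report more compounds than this note shows. Statements on the series, on what has been measured and on what is new or still open speak of the compounds shown alone.

Measured compounds:
compound 1 `Cc1cnc(Nc2ccc(S(C)(=O)=O)cc2)nc1Nc1nc2ccc(Cl)cc2s1` — 4180 nM
compound 2 `Cc1cnc(Nc2ccc(S(C)(=O)=O)cc2)nc1Nc1nc2ccccc2s1` — 460 nM
compound 3 `Cc1cnc(Nc2ccc(S(N)(=O)=O)cc2)nc1Nc1nc2ccc(Cl)cc2s1` — 3730 nM

In a functional assay on HeLa cells (Homo sapiens) for antiproliferative activity, read by MTT assay, with a stated time of 48 h (on this read-out lower numbers stand for stronger inhibition and higher numbers for weaker inhibition), compound 1 gives the highest of the three numbers. Compound 3 sits nearest, a 1.1-fold lower number from compound 1 to compound 3 (0.05 log units; within the scatter), while compound 2 lies furthest, a 9.1-fold lower number from compound 1 to compound 2 (0.96 log units; beyond the scatter). Compound 4 `CS(=O)(=O)c1ccc(Nc2nccc(Nc3nc4ccc(Cl)cc4s3)n2)cc1` differs from compound 1 by hydrogen in place of methyl on an aromatic carbon. Neither measured step touches this position: one alters the chloro on the fused ring, the other the sulfonyl group. No step size can therefore be read across, and no shift beyond the scatter is expected in this assay. Compound 4 is estimated at 4000 nM (range 1300 nM to 12000 nM), meaning an expected step of a 1.0-fold lower number from compound 1 to compound 4 (0.02 log units; within the scatter).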

Compound 4, half-maximal inhibitory concentration: 1400 nM
Compound 4: middle estimate off by 2.9-fold (0.46 log units), on the high side; measured number inside the range.
By their numbers in this assay, from the lowest: compound 2; then compound 4; then compounds 3 and 1 (each within the scatter of the next).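

In this assay, hydrogen in place of methyl on this aromatic carbon gives a 3.0-fold lower number from compound 1 to compound 4 (0.48 log units; beyond the scatter), a step beyond the scatter. This shows that the read-out responds to this position of the shared core, which neither earlier step had touched, and that the methyl is not needed for the activity of compound 1. No measurement shown accounts for this shift. The compounds shown leave open how an ethyl, an amine or a chloro on this aromatic carbon would compare, and whether removing the methyl gives a similar step when the fused ring carries no chloro.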